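A Larger Amine on the Side Chain of Compound 1

The compounds below may be only part of what the source reports. "The series", "measured", "known", "first", "only" and "open" are said of these compounds alone.

Compound 1 `COc1cc2c(Nc3ccc(C#N)cc3)ncnc2cc1OCCCN1CCCCC1` carries a small saturated amine at the end of its side chain. In a functional assay on A549 cells (Homo sapiens) for antiproliferative activity, read by MTT assay, with a stated time of 72 h (on this read-out lower numbers stand for stronger inhibition and higher numbers for weaker inhibition), compound 1 gives 23500 nM, the smaller of the two plain numbers shown, although the step of a 1.8-fold higher number from compound 1 to compound 3 (0.26 log units; within the scatter) is within the scatter, so compound 1 and compound 3 `COc1cc2c(Nc3ccc(C#N)cc3)ncnc2cc1OCCCN1CCC(N(C)C)CC1`, at 42400 nM, cannot be told apart. Compound 2 `COc1cc2c(Nc3ccc(C#N)cc3)ncnc2cc1OCCCN1CCc2ccccc2C1` reaches only a limit of the assay, > 100000 nM. The step of an at least 4.2-fold higher number from compound 1 to compound 2 (0.62 log units; beyond the scatter) and the step of an at least 2.3-fold lower number from compound 2 to compound 3 (0.37 log units; beyond the scatter) both show that the group bearing an aromatic ring went with weaker inhibition.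

Compound 4 `COc1cc2c(Nc3ccc(C#N)cc3)ncnc2cc1OCCCN1CCN(c2ccncc2)CC1` differs from compound 1 by 4-(pyridin-4-yl)piperazin-1-yl in place of piperidin-1-yl on a saturated chain carbon, three bonds along the chain from an oxygen on an aromatic ring. As in compound 2, the entering group is larger and brings an aromatic ring, so the step of an at least 4.2-fold higher number from compound 1 to compound 2 (0.62 log units; beyond the scatter) bears most directly on it, and a modest move toward weaker inhibition is expected, about a 2.6-fold higher number from compound 1 to compound 4 (0.41 log units; beyond the scatter). Compound 4 is therefore estimated at 60000 nM, with a likely range from 25000 nM to 150000 nM.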

Compound 4, half-maximal inhibitory concentration: 25500 nM
Estimate against measurement, compound 4: 2.4-fold (0.37 log units) above; measured number inside the range.
By their numbers in this assay, from the lowest: compounds 1, 4 and 3 (each within the scatter of the next). At a limit, above all of these: compound 2.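

Compound 4 shows that at this saturated chain carbon, a larger amine group bearing an aromatic ring does not by itself go with weaker inhibition in this assay: a 1.1-fold higher number from compound 1 to compound 4 (0.04 log units; within the scatter) and a 1.7-fold lower number from compound 3 to compound 4 (0.22 log units; within the scatter) both lie within the scatter, so compounds 1, 3 and 4 cannot be told apart. The weak result of compound 2 therefore cannot be read as a rule for all such groups, and it stays apart from compound 4, as an at least 3.9-fold lower number from compound 2 to compound 4 (0.59 log units; beyond the scatter) shows. The entry for compound 2 is a limit and not a plain number: the limit of > 100000 nM in this assay, at which 1 of the 4 values shown sits.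

The compounds shown leave open how an amine such as morpholin-4-yl or diethylamino would fare at this place. They also leave open whether a longer chain between the oxygen and the amine would change the result.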